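A few compounds are considered here, and "the series" means these few. Any claim that something is new, unique, unknown or untested is made for them only; others in the source may bear on it.

Compound 1 `NC(=O)N1CCN(C(=S)SCc2cn(Cc3ccc(Cl)cc3)nn2)CC1` and compound 2 `CCNC(=O)N1CCN(C(=S)SCc2cn(Cc3ccc(Cl)cc3)nn2)CC1` share one core and differ by ethyl in place of hydrogen on an amide-type nitrogen. In a functional assay on EC9706 cells (Homo sapiens) for cytotoxicity, read by MTT assay, with a stated time of 72 h (a lower number here means a stronger inhibitor, a higher number a weaker inhibitor), compound 1 gives only a limit, > 128000 nM. Compound 2 likewise gives only a limit in this assay, > 128000 nM. The step that the two limits leave unreadable from compound 1 to compound 2 therefore cannot be read. Compound 3 `COc1cc(Cn2cc(CSC(=S)N3CCN(C(N)=O)CC3)nn2)cc(OC)c1OC` carries another core, and the difference between the two cores is not broken down here. In this assay compound 3 also gives only a limit, > 128000 nM. Compound 4 `CCNC(=O)N1CCN(C(=S)SCc2cn(Cc3cc(OC)c(OC)c(OC)c3)nn2)CC1` differs from compound 3 by ethyl in place of hydrogen on an amide-type nitrogen, the same change as from compound 1 to compound 2 at a place described in the same words. Because the limit of > 128000 nM in this assay, at which 3 of the 3 values shown sit, holds for every measured compound, compound 4 is expected to remain at that limit as well, a step estimated as a step that the limit leaves unreadable from compound 3 to compound 4. The estimate for compound 4 is 160000 nM, expected between 50000 nM and 500000 nM.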

Compound 4, half-maximal inhibitory concentration: > 128000 nM
Compound 4: a limit, no number (the forecaster's own chance of this, stated with the estimate: 85%); the middle value does not contradict the limit.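

Compound 3 and compound 4 both return only limits, so no new step can be read between them, and the ethyl change stays unsized. What the compounds shown leave open is how any of them ranks in this assay, since all sit at one limit: the limit of > 128000 nM in this assay, at which 4 of the 4 values shown sit.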